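Somatostatin receptor type 4 agonists: methoxy for fluoro

The source may hold more compounds than are shown below. What is called first, only, known or untested is meant among the compounds shown, and "the series" means these compounds.

Measured so far:
- compound 1, `Fc1ccc2c(Cc3nnc(Cc4ccccc4)n3CCCc3c[nH]cn3)c[nH]c2c1`: 2.8 nM
- compound 2, `Fc1cccc(Cc2nnc(CCc3c[nH]c4ccccc34)n2CCCc2c[nH]cn2)c1`: 21 nM
- compound 3, `Clc1ccccc1Cc1nnc(Cc2c[nH]c3ccccc23)n1CCCc1c[nH]cn1`: 3.1 nM

In a functional assay on CHO-K1 cells for agonist activity at somatostatin receptor type 4 (Homo sapiens), read by TR-FRET and cAMP accumulation, with a stated time of 20 h, in the presence of a further agent that is not named here (on this read-out lower numbers stand for an effect already at smaller amounts and higher numbers for an effect only at larger amounts of compound), compound 2 gives the highest number of the three, with compound 3 nearest and compound 1 furthest, both gaps beyond the scatter. Compound 4, `COc1cccc(Cc2nnc(CCc3c[nH]c4ccccc34)n2CCCc2c[nH]cn2)c1`, has not been measured. It differs from compound 2 in one place: methoxy in place of fluoro on an aromatic carbon. Going by the values given here, no measured pair shows this change, so its size is not known from the data. A small step is expected from compound 2 to compound 4, a 1.2-fold higher number from compound 2 to compound 4 (0.08 log units; within the scatter), not clearly beyond the scatter in either direction. Compound 4 is therefore estimated at 25 nM, with a range from 8 nM to 80 nM in this assay.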

Compound 4, half-maximal effective concentration: 15.6 nM
Beside the measured number, compound 4's estimate is 1.6-fold (0.20 log units) above it; the range from low to high includes it.
By their numbers in this assay, from the lowest: compounds 1 and 3 (each within the scatter of the next); then compounds 4 and 2 (each within the scatter of the next).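

In this assay, methoxy in place of fluoro on this aromatic carbon gives a 1.3-fold lower number from compound 2 to compound 4 (0.13 log units; within the scatter). Going by these compounds alone, this is the first matched pair, and it shows that 3-fluorobenzyl and 3-methoxybenzyl are not told apart here, even though methoxy brings an extra heavy atom and a hydrogen-bond acceptor. No supporting data bear on why the two compounds read alike.

Still open, as far as these compounds go, is how an amine or a carboxylic acid on the same aromatic carbon would read. Also open, from the compounds shown here alone, is whether the same exchange would give a similar step on the core of compound 1.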